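Sulfonyl aryl variation in the shared core series

A few compounds are considered here, and "the series" means these few. Any claim that something is new, unique, unknown or untested is made for them only; others in the source may bear on it.

Compound 3 `COc1ccc2ncc(S(=O)(=O)c3cccc(F)c3)c(N3CCC(C)CC3)c2c1` gives 68% in an assay on isolated protein for displacement of a labelled ligand from metabotropic glutamate receptor 5 (Homo sapiens), with a stated time of 60 min, tested at 1 uM (on this read-out lower numbers stand for less inhibition and higher numbers for more inhibition at the one concentration tested (going by the name of the read-out)), and stands lowest of the three numbers measured. Compound 1 `CC1CCN(c2c(S(=O)(=O)c3cccc(F)c3)cnc3ccc(F)cc23)CC1` gives 76% in this assay, and the step of a number 8 percentage points lower from compound 1 to compound 3 (within the scatter) lies within the scatter. Compound 2 `COc1ccc2ncc(S(=O)(=O)c3ccc(Cl)cc3)c(N3CCC(C)CC3)c2c1` gives 91% in this assay, and the step of a number 23 percentage points lower from compound 2 to compound 3 (beyond the scatter) is beyond the scatter. Compound 4 `COc1ccc2ncc(S(=O)(=O)c3ccc(C)c(Cl)c3)c(N3CCC(C)CC3)c2c1` is not yet measured; it differs from compound 3 as follows: 3-chloro-4-methylphenyl in place of 3-fluorophenyl on a sulfonyl sulfur. The step of a number 23 percentage points lower from compound 2 to compound 3 (beyond the scatter) bears on this change, since it also replaces the aryl group on the sulfonyl sulfur; from it a modest rise in this assay is expected. The estimate for compound 4 is therefore 85% in this assay, between 70% and 96%, which is the expected step of a number 17 percentage points higher from compound 3 to compound 4 (beyond the scatter).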

Compound 4, a percentage reported as inhibition, at one concentration (the size of the read-out at that concentration, not a potency): 85%
For compound 4 middle estimate and measured number coincide at the digits printed; the range from low to high includes it.
By their numbers in this assay, from the lowest: compounds 3, 1, 4 and 2 (each within the scatter of the next, the first and the last beyond it).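

On the sulfonyl sulfur, 3-chloro-4-methylphenyl in place of 3-fluorophenyl gives a number 17 percentage points higher from compound 3 to compound 4 (beyond the scatter) in this assay, so a second aryl group besides 4-chlorophenyl stands clear of 3-fluorophenyl. Against 4-chlorophenyl, the same group gives a number 6 percentage points lower from compound 2 to compound 4 (within the scatter), so these two aryl groups cannot be told apart on this read-out. Nothing available bears on what underlies the difference from 3-fluorophenyl.

Open, from the compounds shown here alone, is whether an aryl group carrying an amine or a carboxylic acid holds the number at this position. Also open, going by these compounds, is how 3-chloro-4-methylphenyl reads on the core of compound 1.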